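Compound 4: a new substituent on the carbonyl carbon

This account rests on a few compounds, and the source may have more. Where it says the series, first, only, none or still open, it means among the compounds named here.

Three compounds of the series have numbers in a functional assay on PC-3 cells (Homo sapiens) for inhibition, read by sulforhodamine B assay, with a stated time of 48 h (on this read-out higher numbers stand for weaker inhibition and lower numbers for stronger inhibition), so far. Compound 1 `O=C(Nc1cccc(-n2cc(-c3ccncc3)c(-c3ccc(Cl)c(O)c3)n2)c1)Nc1ccc(Cl)c(Cl)c1` gives 830 nM, compound 2 `COc1cc(-c2nn(-c3cccc(NC(=O)c4ccc(Cl)c(C(F)(F)F)c4)c3)cc2-c2ccncc2)ccc1Cl` gives 1290 nM, and compound 3 `COc1cc(-c2nn(-c3cccc(NC(=O)c4cccc(C(F)(F)F)c4)c3)cc2-c2ccncc2)ccc1Cl` gives 1230 nM. Compound 2 carries the highest of these three numbers, but its nearest neighbour is compound 3 and its furthest is compound 1, and both gaps sit within the scatter, so no order among the three can be read. The step from compound 2 to compound 3, hydrogen in place of chloro on an aromatic carbon, gave a 1.0-fold lower number from compound 2 to compound 3 (0.02 log units; within the scatter).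

Compound 4 `COc1cc(-c2nn(-c3cccc(NC(=O)Nc4cccc(C(F)(F)F)c4)c3)cc2-c2ccncc2)ccc1Cl` is not yet measured. It differs from compound 2 by (3-(trifluoromethyl)phenyl)amino in place of 4-chloro-3-(trifluoromethyl)phenyl on a carbonyl carbon. For the measured compounds named here, the only measured step that touches this change is the removal of the same chloro from compound 2 to compound 3, which stayed within the scatter; no measured pair isolates the exchange of the aromatic carbon for an amino group on the carbonyl carbon. Compound 1, which also carries an amino group on its carbonyl carbon among other differences, gives a number within the scatter of compound 2. On this basis the step from compound 2 to compound 4 is expected to be a 1.3-fold lower number from compound 2 to compound 4 (0.11 log units; within the scatter), nothing beyond the scatter in either direction. Compound 4 is therefore estimated at 1000 nM, with a range from 400 nM to 2500 nM.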

Compound 4, half-maximal inhibitory concentration: 370 nM
The estimate for compound 4 lay 2.7-fold (0.43 log units) above the measured number; measured number below the stated range.
By their numbers in this assay, from the lowest: compound 4; then compounds 1, 3 and 2 (each within the scatter of the next).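

In this assay, for the compounds shown here, the substituent on the carbonyl carbon is the first place where a single change moves the number beyond the scatter. The cleanest reading is a 3.3-fold lower number from compound 3 to compound 4 (0.52 log units; beyond the scatter), where (3-(trifluoromethyl)phenyl)amino replaces 3-(trifluoromethyl)phenyl, and the step holds with the chloro-bearing partner too (a 3.5-fold lower number from compound 2 to compound 4 (0.54 log units; beyond the scatter)), whereas loss of chloro alone had stayed within the scatter (a 1.0-fold lower number from compound 2 to compound 3 (0.02 log units; within the scatter)). Nothing measured here explains why the amino group lowers the number.

Open, on these data alone, is whether the amino hydrogen itself matters, which a methylamino group or an oxygen link on the carbonyl carbon would test. Also open, as far as these compounds go, is whether a chloro on the phenyl ring of compound 4 stays as silent as it did in the step between compound 2 and compound 3.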